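Adding a Second Methyl to the Aryl Amide of Compound 3

The source may report more compounds than this note shows. Statements on the series, on what has been measured and on what is new or still open speak of the compounds shown alone.

Compound 1 `Cc1cc(C(=O)NCN2CCC(c3cccc[n+]3[O-])CC2)ccc1F`: 67%
Compound 2 `C=Cc1cccc(C(=O)NCN2CCC(c3cccc[n+]3[O-])CC2)c1`: 63%
Compound 3 `Cc1cccc(C(=O)NCN2CCC(c3cccc[n+]3[O-])CC2)c1`: 77%

In a functional assay on HEK293 cells for agonist activity at D(4) dopamine receptor (Homo sapiens), read by FLIPR (a lower number here means a smaller maximal response, a higher number a larger maximal response), compound 3 gives 77%, the highest of the three numbers; compound 1 lies nearest with 67%, a gap within the scatter, and compound 2 lies furthest with 63%, a gap beyond it. Compound 4 `Cc1cc(C)cc(C(=O)NCN2CCC(c3cccc[n+]3[O-])CC2)c1` differs from compound 3 by methyl in place of hydrogen on an aromatic carbon, on an aromatic carbon of the six-membered carbon ring, meta to a large group and meta to a methyl group. Among the measured compounds shown here, no measured step adds a methyl to this ring; the steps that touch it are a number 14 percentage points higher from compound 2 to compound 3 (beyond the scatter), a modest change, and a number 10 percentage points higher from compound 1 to compound 3 (within the scatter), within the scatter. Neither gives a clear lead on a second methyl, so for compound 4 no step beyond the scatter is expected, and its estimated step is a number 2 percentage points lower from compound 3 to compound 4 (within the scatter). Compound 4 is therefore estimated at 75%, with a range from 60% to 90%.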

Compound 4, largest response reached (reported as efficacy), in percent of the reference or control that the assay uses: 56%
Estimate against measurement, compound 4: 19 percentage points above, outside the stated range (below it).
By their numbers in this assay, from the lowest: compounds 4, 2, 1 and 3 (each within the scatter of the next, the first and the last beyond it).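

Moving from 3-methylphenyl to 3,5-dimethylphenyl shows that in this assay this position is sensitive to a single added methyl, meta to a large group and meta to a methyl group: the result is a number 21 percentage points lower from compound 3 to compound 4 (beyond the scatter). Compared with the other two aryl amides, the result is mixed, with a number 11 percentage points lower from compound 1 to compound 4 (beyond the scatter) but only a number 7 percentage points lower from compound 2 to compound 4 (within the scatter), which leaves compound 4 not separated from compound 2. No measurement is available that would explain this drop in maximal response.

The compounds shown leave open whether a chlorine atom, a methoxy group or an amine on this same carbon would behave as the methyl does. They also leave open whether a second methyl on another carbon of this ring would give a similar step.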